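Thiophen-2-yl to thiophen-3-yl on a second core

This account rests on a few compounds, and the source may have more. Where it says the series, first, only, none or still open, it means among the compounds named here.

Of the compounds shown here, three have been measured in a functional assay on K562 cells (Homo sapiens) for inhibition, read by thymidine incorporation, with a stated time of 48 h, tested at 10 ug/mL; a lower number here means less inhibition, a higher number more inhibition at the concentration tested (going by the name of the read-out). Compound 1 `C(=C/c1[nH]cnc2ncnc1-2)\c1cccs1` gives 50% and compound 3 `C(=C/c1[nH]cnc2ncnc1-2)\c1ccsc1` gives 32%; the two differ only in thiophen-3-yl in place of thiophen-2-yl on a double-bonded chain carbon bound to a double-bonded chain carbon, and that change gave a number 18 percentage points lower from compound 1 to compound 3 (beyond the scatter). Compound 2 `C(=C/c1ncnc2c1ncn2C1CCOCC1)\c1cccs1` gives 65%, the highest of the three numbers, its steps to compound 1 and to compound 3 both beyond the scatter. The difference between the core of compound 2 and the core of compound 1 is not broken down here.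

Compound 4 `C(=C/c1ncnc2c1ncn2C1CCOCC1)\c1ccsc1` is not yet measured. It differs from compound 2 by thiophen-3-yl in place of thiophen-2-yl on a double-bonded chain carbon bound to a double-bonded chain carbon, at the same place as the change from compound 1 to compound 3, so it is the same change carried onto the core of compound 2. Among the measured compounds shown here, only one earlier instance exists, so a step of about the same size is expected, a number 18 percentage points lower from compound 2 to compound 4 (beyond the scatter). This rests on compound 2 at 65% and on a number 18 percentage points lower from compound 1 to compound 3 (beyond the scatter). The estimate for compound 4 in this assay is 47%, expected to lie between 32% and 62%. Whether the change carries across cores cannot be judged from one pair.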

Compound 4, a percentage reported as inhibition, at one concentration (the size of the read-out at that concentration, not a potency): 58%
The estimate for compound 4 lay 11 percentage points below the measured number, within the range that was stated.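

In this assay, thiophen-3-yl in place of thiophen-2-yl on the second core gave a number 7 percentage points lower from compound 2 to compound 4 (within the scatter). Set beside the first instance of the change, this step does not differ from it by more than two such steps can scatter: the same change on two cores in this assay, a number 18 percentage points lower (beyond the scatter) from compound 1 to compound 3 and a number 7 percentage points lower (within the scatter) from compound 2 to compound 4, 11 percentage points apart, within the scatter of two such steps. Among the compounds shown here, the two pairs therefore give no ground for saying that the change behaves differently on the two cores, but they do not show that it carries over at a fixed size, as only one of the two steps lies beyond the scatter and the comparison rests on two pairs read at a single concentration.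

The compounds shown carry only the two thiophene attachments at the end of the chain, so a phenyl or furan-2-yl ring in that place remains open, as does an amine or a carboxylic acid on the ring. Going by these compounds, whether the same change would hold on a third core also stays open.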